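Hydroxyphenyl placement on the trifluoromethoxyphenyl analogue

A few compounds are considered here, and "the series" means these few. Any claim that something is new, unique, unknown or untested is made for them only; others in the source may bear on it.

Compound 3 `Oc1cccc(-c2cc(-c3ccccc3OC(F)(F)F)cc(-c3cccc(O)c3)n2)c1` gives 16700 nM in a functional assay on HeLa cells (Homo sapiens) for inhibition; a lower number here means a stronger inhibitor, a higher number a weaker inhibitor. The two other measured compounds sit within the scatter of that number: compound 1 `Oc1ccc(-c2cc(-c3ccccc3F)cc(-c3cccc(O)c3)n2)cc1` gives 14300 nM, and compound 2 `Oc1ccc(-c2cc(-c3ccccc3C(F)(F)F)cc(-c3cccc(O)c3)n2)cc1` gives 17400 nM. Among the measured compounds shown here, the one measured step, a 1.2-fold higher number from compound 1 to compound 2 (0.09 log units; within the scatter), concerns a different position on the core and does not bear on the change considered here. Compound 4 `Oc1ccc(-c2cc(-c3ccccc3OC(F)(F)F)cc(-c3cccc(O)c3)n2)cc1` differs from compound 3 by 4-hydroxyphenyl in place of 3-hydroxyphenyl on an aromatic carbon. Compounds 1 and 2 already carry this 4-hydroxyphenyl arrangement and give numbers close to compound 3, so no step beyond the scatter is expected: a 1.0-fold lower number from compound 3 to compound 4 (0.02 log units; within the scatter). For compound 4 the estimate in this assay is 16000 nM, with a range from 8000 nM to 32000 nM.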

Compound 4, half-maximal inhibitory concentration: 5800 nM
Estimate against measurement, compound 4: 2.8-fold (0.44 log units) above; measured number below the stated range.
By their numbers in this assay, from the lowest: compound 4; then compounds 1, 3 and 2 (each within the scatter of the next).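

In this assay, among the compounds shown here, with trifluoromethoxy held in place, 4-hydroxyphenyl in place of 3-hydroxyphenyl gives a step beyond the scatter, a 2.9-fold lower number from compound 3 to compound 4 (0.46 log units; beyond the scatter), which the earlier compounds could not show. With 4-hydroxyphenyl held in place, trifluoromethoxy also stands apart from the other two groups, a 3.0-fold lower number from compound 2 to compound 4 (0.48 log units; beyond the scatter) and a 2.5-fold lower number from compound 1 to compound 4 (0.39 log units; beyond the scatter), although fluoro and trifluoromethyl stay within the scatter of each other. No measured evidence bears on these steps.

From the compounds shown here alone, whether the 4-hydroxyphenyl step also holds with fluoro or trifluoromethyl remains open. So does the effect of an amine or a carboxylic acid in place of the hydroxyl.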